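From methylamino to dimethylamino: compound 3 to compound 4

The source may hold more compounds than are shown below. What is called first, only, known or untested is meant among the compounds shown, and "the series" means these compounds.

In a functional assay on HCT-116 cells (Homo sapiens) for antiproliferative activity, read by MTT assay, with a stated time of 48 h (on this read-out lower numbers stand for stronger inhibition and higher numbers for weaker inhibition), compound 1 (`CCCCCCCC(CCO)n1cnc2c(N(C)C)ncnc21`) reads > 50000 nM which is a limit of the assay and not a number. Compound 2 (`CCCCCCCCC(CCO)n1cnc2c(N(C)C)ncnc21`) gives 19800 nM and compound 3 (`CCCCCCCCCCC(CCO)n1cnc2c(NC)ncnc21`) gives 12700 nM and these two values lie within the scatter of each other. Compound 4 (`CCCCCCCCCCC(CCO)n1cnc2c(N(C)C)ncnc21`) differs from compound 3 by methyl in place of hydrogen on a nitrogen on an aromatic ring with methyl in place of hydrogen on a nitrogen on an aromatic ring. Among the compounds with values here, the one measured step of an at least 2.5-fold lower number from compound 1 to compound 2 (0.40 log units; beyond the scatter) puts methyl on a saturated chain carbon instead, so no measured step covers this nitrogen. Only a small move towards a lower number is therefore expected. The expected change is a 1.3-fold lower number from compound 3 to compound 4 (0.10 log units; within the scatter) in this assay and stays within the scatter. Compound 4 is estimated at 10000 nM with an expected range of 4000 nM to 25000 nM in this series.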

Compound 4, half-maximal inhibitory concentration: 5490 nM
Beside the measured number, compound 4's estimate is 1.8-fold (0.26 log units) above it, within the range that was stated.
By their numbers in this assay, from the lowest: compound 4; then compounds 3 and 2 (each within the scatter of the next). At a limit, above all of these: compound 1.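

In this assay, within the data shown here, the nitrogen on the aromatic ring responds to substitution: a 2.3-fold lower number from compound 3 to compound 4 (0.36 log units; beyond the scatter), the first measured step at this position. With dimethylamino held, the chain also matters, and compound 4 carries the longest chain of this set: a 3.6-fold lower number from compound 2 to compound 4 (0.56 log units; beyond the scatter). The step of an at least 9.1-fold lower number from compound 1 to compound 4 (0.95 log units; beyond the scatter) starts from a limit and not a number: the limit of > 50000 nM in this assay, at which 1 of the 4 values shown sits.

From the compounds shown here alone, whether an unsubstituted amino group, diethylamino or a pyrrolidine on this nitrogen would continue the trend stays open. So does the effect of a still longer chain with dimethylamino held.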